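Methyl Position Swap on a Sulfonamide Series at the Limit

A few compounds are considered here, and "the series" means these few. Any claim that something is new, unique, unknown or untested is made for them only; others in the source may bear on it.

The series is followed in an assay on isolated protein for inhibition of malate dehydrogenase, mitochondrial (Sus scrofa), with stated times of 45 min and 30 min; on this read-out lower numbers stand for stronger inhibition and higher numbers for weaker inhibition. Compound 1 `Cc1ccc(S(=O)(=O)Nc2ccc3oc(-c4ccccc4)nc3c2)cc1` returns only a limit, > 63000 nM, and no number. Compound 2 `O=S(=O)(Nc1ccc2oc(-c3ccccc3)nc2c1)c1ccc(F)c(C(F)(F)F)c1` likewise gives only a limit, > 63000 nM, in this assay. Compound 3 `C=Cc1ccc(S(=O)(=O)Nc2ccc(-c3nc4ccccc4o3)cc2)cc1`, in which the shared core is attached through a different ring position, also stops at a limit, > 63000 nM. Thus compound 1 stands nowhere on a numeric scale: it sits at the limit of > 63000 nM in this assay, at which 3 of the 3 values shown sit, alongside both other measured compounds, so no step between measured compounds can be sized.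

Compound 4 `Cc1cccc(S(=O)(=O)Nc2ccc3oc(-c4ccccc4)nc3c2)c1` carries 3-methylphenyl in place of 4-methylphenyl on a sulfonyl sulfur. For the measured compounds named here, because every measured analogue sits at the limit of > 63000 nM in this assay, at which 3 of the 3 values shown sit, there is no step in this assay from which the size or direction of a change for compound 4 could be read; the methyl group only moves within the same ring. The expectation is therefore no movement beyond the scatter: the step from compound 1 to compound 4 is estimated as a step that the limit leaves unreadable from compound 1 to compound 4. Compound 4 is expected to give 100000 nM, within 40000 nM to 300000 nM, most likely again reported only as a limit.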

Compound 4, half-maximal inhibitory concentration: > 63000 nM
Compound 4 gave a limit, no number (the forecaster's own chance of this, stated with the estimate: 85%); the middle value does not contradict the limit.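

In this assay, for the compounds shown here, compound 4, like compound 1, returns a limit and no number, so no step between them can be read: the limit of > 63000 nM in this assay, at which 4 of the 4 values shown sit.

The compounds shown leave open whether any change to the sulfonamide series gives a numeric value in this assay.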